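Replacing a Ring-Bearing Alcohol with a Plain Butyl Chain

This account rests on a few compounds, and the source may have more. Where it says the series, first, only, none or still open, it means among the compounds named here.

Measured so far:
Compound 1, `C=CCn1c(=O)n(C2CCC(CO)C2)c2nc(N)nc(O)c21`: 0%
Compound 2, `CC1(C)O[C@@H]2[C@H](O1)[C@@H](CO)O[C@H]2n1c(=O)n(C/C=C/c2ccccc2)c2c(O)nc(N)nc21`: 10%

Both measured compounds were tested in a functional assay on the whole organism with Mus musculus as the target; on this read-out higher numbers stand for larger maximal responses and lower numbers for smaller maximal responses. Compound 1 gives 0%, and compound 2 gives 10%. The two numbers sit within the usual scatter of each other, so neither compound can be set apart from the other; compound 1 and compound 2 both show essentially no response in this assay.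

Compound 3, `C=CCn1c(=O)n(CCCC)c2nc(N)nc(O)c21`, has not yet been measured. It differs from compound 1 in one place: a group of 4 heavy atoms (4 carbon; no ring) in place of a group of 7 heavy atoms (6 carbon, 1 oxygen; one five-membered non-aromatic ring of carbon only), on an aromatic nitrogen. Going by the values given here, no step between two measured compounds is known here, so nothing tells how such a swap on an aromatic nitrogen of the shared core moves the response.

With both known numbers at the floor, compound 3 is expected to stay there too, and the step of a number 5 percentage points higher from compound 1 to compound 3 (within the scatter) is expected to be none beyond the scatter. Compound 3 is therefore estimated at 5%, within a range from 0% to 30%, because compound 1 gives 0% and compound 2 gives 10%.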

Compound 3, largest response reached (reported as maximal response), in percent of the reference or control that the assay uses: 36%
Compound 3: the middle estimate sits 31 percentage points below what was measured; measured number above the stated range.
By their numbers in this assay, from the lowest: compounds 1 and 2 (each within the scatter of the next); then compound 3.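

In this assay, putting butyl in place of the ring-bearing alcohol group on the aromatic nitrogen of the shared core gives a number 36 percentage points higher from compound 1 to compound 3 (beyond the scatter), so this position is not silent: what sits there can decide whether a response appears at all. The group that leaves holds a five-membered carbon ring and a hydroxyl, while butyl is an open chain of carbon alone, which shows that neither the ring nor the hydroxyl is required for a response on this core. Nothing measured on these compounds tells why the response moves with this swap.

The single swap changes several things at once, so the compounds shown cannot separate the loss of the ring from the loss of the hydroxyl; a plain cyclopentyl group, or a four-carbon chain ending in a hydroxyl, would pull these two apart. Going by these compounds, how far the response depends on chain length also remains open, and a propyl or hexyl chain at the same nitrogen would show whether butyl is a special case or one point on a trend.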